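The source may hold more compounds than are shown below. What is called first, only, known or untested is meant among the compounds shown, and "the series" means these compounds.

Measured so far:
- compound 1, `O=[N+]([O-])c1ccc(-c2nc3ccccc3o2)cc1`: 36000 nM
- compound 2, `Cc1ccc2nc(-c3ccc([N+](=O)[O-])cc3)oc2c1`: 18000 nM

In an assay on cells for inhibition of matrix metalloproteinase-9 (Homo sapiens), read by fluorescence, with stated times of 15 min and 4 h (on this read-out lower numbers stand for stronger inhibition and higher numbers for weaker inhibition), compound 1 gives 36000 nM, the highest of the two numbers measured. Its nearest neighbour is compound 2, which gives 18000 nM; the change between them is a 2.0-fold lower number from compound 1 to compound 2 (0.30 log units; within the scatter), so the two compounds cannot be told apart on this read-out.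

Compound 3, `Cc1ccc2oc(-c3ccc([N+](=O)[O-])cc3)nc2c1`, has not yet been measured. It differs from compound 1 by methyl in place of hydrogen on an aromatic carbon. Among the measured compounds shown here, the one measured step that bears on this is the same kind of change made on the same ring of the shared core, and that step was within the scatter. On that basis the change is expected to give no step beyond the scatter in this assay, that is a 1.6-fold lower number from compound 1 to compound 3 (0.21 log units; within the scatter). Compound 3 is therefore estimated at 22000 nM, with a likely range from 9000 nM to 50000 nM.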

Compound 3, half-maximal inhibitory concentration: 14900 nM
Beside the measured number, compound 3's estimate is 1.5-fold (0.17 log units) above it, within the range that was stated.
By their numbers in this assay, from the lowest: compounds 3, 2 and 1 (each within the scatter of the next, the first and the last beyond it).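

In this assay, methyl in place of hydrogen on this aromatic carbon of the six-membered ring of carbon only gives a 2.4-fold lower number from compound 1 to compound 3 (0.38 log units; beyond the scatter). Unlike the methyl step to compound 2, which stayed within the scatter, this one clears it, although only modestly, so a single methyl on this ring of the shared core can produce a measurable change in the number. Compound 2 and compound 3 nevertheless lie within the scatter of each other, so the data do not separate these two methyl placements, and nothing measured here accounts for the step.

The compounds shown leave open whether an ethyl group, a longer chain or an amine on this carbon would give a larger step or a smaller one. They also leave open whether the step would hold if the nitro group on the shared core were replaced by a carboxylic acid or a nitrile.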